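The compounds below may be only part of what the source reports. "The series", "measured", "known", "first", "only" and "open" are said of these compounds alone.

Compound 2, `COc1ccc2[nH]c(C(=O)N3CC(=O)N(Cc4ccccc4)[C@@H](CN4CCCC4)C3)cc2c1`, and compound 1, `COc1ccc2[nH]c(C(=O)N3CC(=O)N(Cc4ccccc4)[C@@H](CN4CCC(OC)CC4)C3)cc2c1`, share one core and differ only on the saturated chain carbon bound to a saturated ring carbon. In a physicochemical assay for solubility, read by spectrophotometry, in phosphate buffer, with a stated time of 2 h, at pH 7.4 (on this read-out higher numbers stand for higher solubility and lower numbers for lower solubility), compound 1 gives > 25000 nM, which is a limit of the assay rather than a number. In this assay compound 2 likewise gives > 25000 nM, again a limit. The step that the two limits leave unreadable from compound 1 to compound 2 therefore cannot be read in size, and the limit of > 25000 nM in this assay, at which 2 of the 2 values shown sit, is all the two values show; compound 2 thus stands at the limit with no number beneath it. Compound 3, `COc1ccc2[nH]c(C(=O)N3CC(=O)N(Cc4ccccc4)[C@@H](COc4ccc(F)cc4)C3)cc2c1`, carries 4-fluorophenoxy in place of pyrrolidin-1-yl on a saturated chain carbon bound to a saturated ring carbon. Within the data shown here, no measured step bears on this change in a readable size, so any expectation rests on the limit alone. The estimate for compound 3 in this assay is 8000 nM, within a range from 1500 nM to 25000 nM. This estimate means an expected step of an at least 3.1-fold lower number from compound 2 to compound 3 (0.49 log units; beyond the scatter), downward and beyond the scatter.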

Compound 3, solubility: 17500 nM
Estimate against measurement, compound 3: 2.2-fold (0.34 log units) below; the range from low to high includes it.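

Compound 3 gives a number in this assay rather than a limit, so the saturated chain carbon bound to a saturated ring carbon now has one readable value, carried by 4-fluorophenoxy. The change to that group reads as an at least 1.4-fold lower number from compound 2 to compound 3 (0.15 log units; that floor lies within the scatter), and from the other amine it reads as an at least 1.4-fold lower number from compound 1 to compound 3 (0.15 log units; that floor lies within the scatter); each is only a floor, so neither step yet establishes a real drop. The step between the two amine compounds still cannot be read, and both remain at a limit of the assay: the limit of > 25000 nM in this assay, at which 2 of the 3 values shown sit.

As far as these compounds go, how far compound 1 and compound 2 lie past that limit stays open, and with it the true size of both new steps. Also open, from the compounds shown here alone, is what a plain phenoxy or a carboxylic acid would give on a saturated chain carbon bound to a saturated ring carbon.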